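Tertiary piperidine amides versus secondary cyclic-ether amides

This account rests on a few compounds, and the source may have more. Where it says the series, first, only, none or still open, it means among the compounds named here.

Compound 3 `CCN(CC)S(=O)(=O)c1ccc(S(=O)(=O)N2CCC[C@@H](C(=O)N[C@H]3CCOC3)C2)cc1` gives 1670 nM in a functional assay on MIA PaCa-2 cells (Homo sapiens) for inhibition, read by MTT assay, with a stated time of 7 days; on this read-out lower numbers stand for stronger inhibition and higher numbers for weaker inhibition. Of the three measured compounds it stands second highest: a 1.4-fold lower number from compound 2 to compound 3 (0.15 log units; within the scatter), whereas a 12-fold higher number from compound 1 to compound 3 (1.08 log units; beyond the scatter). Compound 1 `CCN(CC)S(=O)(=O)c1ccc(S(=O)(=O)N2CCC[C@@H](C(=O)N3CCC(OC)CC3)C2)cc1` gives 140 nM in this assay and compound 2 `CCN(CC)S(=O)(=O)c1ccc(S(=O)(=O)N2CCC[C@@H](C(=O)NC3COC3)C2)cc1` gives 2340 nM. The two large steps, a 17-fold higher number from compound 1 to compound 2 (1.22 log units; beyond the scatter) and a 12-fold higher number from compound 1 to compound 3 (1.08 log units; beyond the scatter), both separate the tertiary piperidine amide from the secondary amides to small cyclic ethers; the step between the two secondary amides is within the scatter.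

Compound 4 `CCN(CC)S(=O)(=O)c1ccc(S(=O)(=O)N2CCC[C@@H](C(=O)N3CCC(C(F)(F)F)CC3)C2)cc1` differs from compound 3 in that (4-(trifluoromethyl)piperidin-1-yl in place of (oxolan-3-yl)amino on a carbonyl carbon). The step that bears on this change is the reverse of a 12-fold higher number from compound 1 to compound 3 (1.08 log units; beyond the scatter), so a return to a tertiary piperidine amide is expected to give a markedly lower number in this assay. Among the measured compounds shown here, the trifluoromethyl group on the piperidine has no measured counterpart among the three compounds, so the size of the return is uncertain. Compound 4 is expected at 250 nM, within 80 nM to 800 nM, which amounts to an expected 6.7-fold lower number from compound 3 to compound 4 (0.82 log units; beyond the scatter).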

Compound 4, half-maximal inhibitory concentration: 320 nM
Compound 4: the middle estimate sits 1.3-fold (0.11 log units) below what was measured; measured number inside the range.
By their numbers in this assay, from the lowest: compound 1; then compound 4; then compounds 3 and 2 (each within the scatter of the next).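

In this assay the lower numbers of the tertiary piperidine amides now rest on a second example, with 4-(trifluoromethyl)piperidin-1-yl on the carbonyl carbon: a 5.2-fold lower number from compound 3 to compound 4 (0.72 log units; beyond the scatter) and a 7.3-fold lower number from compound 2 to compound 4 (0.86 log units; beyond the scatter). The substituent on the piperidine also counts, since trifluoromethyl in place of methoxy on a saturated ring carbon gives a 2.3-fold higher number from compound 1 to compound 4 (0.36 log units; beyond the scatter), so the amide type alone does not set the number. Nothing at hand accounts for these steps.

Whether the lower numbers follow the piperidine ring itself or the tertiary amide stays open, as the compounds shown do not separate the two. Also open, as far as these compounds go, is how a piperidine carrying a hydroxyl group, an amine or a carboxylic acid in that place would read.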